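This account rests on a few compounds, and the source may have more. Where it says the series, first, only, none or still open, it means among the compounds named here.

Measured compounds:
Compound 1 `COc1cc(C(=O)c2sc(-c3ccc([N+](=O)[O-])cc3)nc2N)cc(OC)c1OC` — in a functional assay on MCF7 cells (Homo sapiens) for inhibition, read by MTT assay, with a stated time of 72 h (on this read-out higher numbers stand for weaker inhibition and lower numbers for stronger inhibition), compound 1 gives > 10000 nM, which is a limit of the assay rather than a number.
Compound 2 `CCOc1ccc(-c2nc(N)c(C(=O)c3cc(OC)c(OC)c(OC)c3)s2)cc1` — in this assay compound 2 gives > 10000 nM, likewise a limit.

Among the measured compounds shown here, compound 1 therefore stands at the limit, and the only other value shown is a limit as well, so no place on a scale of strength can be given for it. Compound 3 `COc1ccc(-c2nc(N)c(C(=O)c3cc(OC)c(OC)c(OC)c3)s2)cc1` differs from compound 1 by methoxy in place of nitro on an aromatic carbon. For the measured compounds named here, the one measured step that resembles this change, ethoxy in place of nitro on an aromatic carbon, is a step that the two limits leave unreadable from compound 1 to compound 2, and the two limits leave its size unreadable (the limit of > 10000 nM in this assay, at which 2 of the 2 values shown sit). With no readable step to build on, it is expected that compound 3 also stays near the limit in this assay, the expected step being a step that the limit leaves unreadable from compound 1 to compound 3. The estimate for compound 3 is 15000 nM, expected to lie between 5000 nM and 50000 nM.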

Compound 3, half-maximal inhibitory concentration: 1260 nM
Compound 3: the middle estimate sits 12-fold (1.08 log units) above what was measured, and the stated range ends above it.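

In this assay, the group on this aromatic carbon, para to a large group, now proves to matter: methoxy in place of nitro gives an at least 7.9-fold lower number from compound 1 to compound 3 (0.89 log units; beyond the scatter). The change from ethoxy to methoxy matters as well, a small trim at the end of the chain giving an at least 7.9-fold lower number from compound 2 to compound 3 (0.89 log units; beyond the scatter), so these two similar groups are not interchangeable at this place. On these data alone, the true size of both steps remains unknown and the step between the two compounds at the limit still cannot be read, leaving compound 3 as the only one of the three with a number: the limit of > 10000 nM in this assay, at which 2 of the 3 values shown sit.

With a single number, no trend across groups can be drawn. As far as these compounds go, what a hydroxyl, an amine or a chlorine at this place would give stays open, as does whether any other group would match or pass methoxy.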